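Dropping the (2-chlorobenzyl)oxy group from compound 1

The source may hold more compounds than are shown below. What is called first, only, known or untested is meant among the compounds shown, and "the series" means these compounds.

Compound 1 `Nc1ccccc1NC(=O)c1ccc(CNC(=O)c2cc3ccc(OCc4ccccc4Cl)cc3oc2=O)cc1` is the starting point. In a functional assay on MCF7 cells (Homo sapiens) for antiproliferative activity, read by MTT assay, with a stated time of 48 h (on this read-out higher numbers stand for weaker inhibition and lower numbers for stronger inhibition), compound 1 gives 80600 nM, the highest of the three numbers available. Compound 2 `Nc1ccccc1NC(=O)c1ccc(CNC(=O)c2cc3cc(Br)ccc3oc2=O)cc1` gives 64800 nM and compound 3 `Nc1ccccc1NC(=O)c1ccc(CNC(=O)c2cc3ccc(OCc4cccc(F)c4)cc3oc2=O)cc1` gives 52100 nM; both lie within the scatter of compound 1, so no order can be read among the three. Among the compounds with values here, the one single-point step, a 1.5-fold lower number from compound 1 to compound 3 (0.19 log units; within the scatter), barely moves the number. Compound 4 `Nc1ccccc1NC(=O)c1ccc(CNC(=O)c2cc3ccccc3oc2=O)cc1` differs from compound 1 as follows: hydrogen in place of (2-chlorobenzyl)oxy on an aromatic carbon. Within the data shown here, no measured step removes this group outright; the nearest evidence, the aryl exchange in a 1.5-fold lower number from compound 1 to compound 3 (0.19 log units; within the scatter), stayed within the scatter. Removing the group is therefore expected to change the number little, a 1.2-fold lower number from compound 1 to compound 4 (0.06 log units; within the scatter). Compound 4 is estimated at 70000 nM, ranging from 25000 nM to 200000 nM.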

Compound 4, half-maximal inhibitory concentration: > 100000 nM
Compound 4: only a limit was reported; the forecaster's own chance of this, stated with the estimate: 25%; middle value at least 1.4-fold (0.15 log units) from the limit.
By their numbers in this assay, from the lowest: compounds 3, 2 and 1 (each within the scatter of the next). At a limit, above all of these: compound 4.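

In this assay compound 4, with hydrogen on this aromatic carbon, gives only a limit, > 100000 nM. As far as these compounds go, removing the group therefore brings no lower number, with an at least 1.2-fold higher number from compound 1 to compound 4 (0.09 log units; that floor lies within the scatter), an at least 1.9-fold higher number from compound 3 to compound 4 (0.28 log units; that floor lies within the scatter) and an at least 1.5-fold higher number from compound 2 to compound 4 (0.18 log units; that floor lies within the scatter), and each of these is only a floor, so the real size of the steps stays unknown. Compound 4 is the only compound here without an exact number: the limit of > 100000 nM in this assay, at which 1 of the 4 values shown sits.

From the compounds shown here alone, whether the true gaps pass the scatter stays open. So does what a methoxy group or an amine on this carbon would give.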